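The compounds below may be only part of what the source reports. "The series", "measured", "known", "first", "only" and "open" are said of these compounds alone.

Compound 1 `N#Cc1c(O)nc(SCc2nc3ccccc3[nH]2)nc1-c1ccccc1` gives 3.43 nM in a functional assay on G-361 cells (Homo sapiens) for cytotoxicity, read by MTT assay, with a stated time of 3 days; on this read-out lower numbers stand for stronger inhibition and higher numbers for weaker inhibition. Compound 2 `N#Cc1c(NN)nc(SCc2nc3ccccc3[nH]2)nc1-c1ccccc1` gives 14.7 nM. Compound 3 `CNc1nc(SCc2nc3ccccc3[nH]2)nc(-c2ccccc2)c1C#N` gives 12.5 nM.

Compound 3 has the second highest of these three numbers; its value and that of compound 2 sit within the scatter of each other, while the rise a 3.6-fold higher number from compound 1 to compound 3 (0.56 log units; beyond the scatter) lies beyond it. Compound 4 `N#Cc1c(NC(N)=S)nc(SCc2nc3ccccc3[nH]2)nc1-c1ccccc1` differs from compound 3 by a group of 3 heavy atoms (1 carbon, 1 nitrogen, 1 sulfur; no ring) in place of one carbon atom, on a nitrogen on an aromatic ring. Within the data shown here, the only earlier step at this same nitrogen, a 1.2-fold lower number from compound 2 to compound 3 (0.07 log units; within the scatter), stayed within the scatter, so an exchange of the group on that nitrogen has so far left the number much as it was; the steps of a 4.3-fold higher number from compound 1 to compound 2 (0.63 log units; beyond the scatter) and a 3.6-fold higher number from compound 1 to compound 3 (0.56 log units; beyond the scatter) came instead from replacing the hydroxy on the aromatic carbon. Compound 4 is therefore expected to give 15 nM, between 5 nM and 45 nM, a step of a 1.2-fold higher number from compound 3 to compound 4 (0.08 log units; within the scatter).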

Compound 4, half-maximal inhibitory concentration: 5.81 nM
For compound 4 the middle estimate is 2.6-fold (0.41 log units) above the measured one; low and high end bracket the measured number.
By their numbers in this assay, from the lowest: compounds 1 and 4 (each within the scatter of the next); then compounds 3 and 2 (each within the scatter of the next).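

In this assay the group on this nitrogen does count: a 2.2-fold lower number from compound 3 to compound 4 (0.33 log units; beyond the scatter) and a 2.5-fold lower number from compound 2 to compound 4 (0.40 log units; beyond the scatter) both lie beyond the scatter, which the earlier exchange of methyl for amino there did not. Also, a 1.7-fold higher number from compound 1 to compound 4 (0.23 log units; within the scatter) stays within the scatter, unlike the other two replacements of the hydroxy on the aromatic carbon. No measurement here explains why this group behaves differently from the others. Still open, as far as these compounds go, is whether the sulfur matters, which an oxygen in its place would test, and how a longer chain on this nitrogen would fare.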